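The compounds below may be only part of what the source reports. "The series", "measured", "known", "first", "only" and "open" are said of these compounds alone.

Measured so far in an assay on CHO cells with metabotropic glutamate receptor 2 (Homo sapiens) as the target, read by FLIPR; a higher number here means that more compound is needed for the effect, a lower number that less compound is needed:
Compound 1, `Cn1c(CN2CCC(c3ccccc3)CC2)nc2ccccc21`, gives 200 nM.
Compound 2, `Cn1c(CN2CCN(c3ccc(Cl)cc3F)CC2)nc2ccccc21`, gives 126 nM.
Compound 3, `Cn1c(CN2CCC(c3ccccc3C(F)(F)F)CC2)nc2ccccc21`, gives 316 nM.

Compound 2 has the lowest number of the three; its gap to compound 1 lies within the scatter, its gap to compound 3 beyond it. Compound 4, `Cn1c(CN2CCN(c3ccccn3)CC2)nc2ccccc21`, differs from compound 2 by pyridin-2-yl in place of 4-chloro-2-fluorophenyl on an amine nitrogen in a ring. For the measured compounds named here, the only measured step, a 1.6-fold higher number from compound 1 to compound 3 (0.20 log units; within the scatter), concerns a substituent on a ring carbon, not an exchange of the whole aromatic ring, so it bears on this change only loosely. Going by the values given here, no measured pair shows what removing the chlorine and fluorine or bringing in a ring nitrogen does here. With so little to go on, the number for compound 4 is expected to stay near that of compound 2, with a slightly higher number somewhat more likely. For compound 4 the estimate in this assay is 300 nM, with a range from 100 nM to 1000 nM. That estimate means an expected 2.4-fold higher number from compound 2 to compound 4 (0.38 log units; beyond the scatter).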

Compound 4, half-maximal effective concentration: 15800 nM
Estimate against measurement, compound 4: 53-fold (1.72 log units) below; measured number outside the range, above it.
By their numbers in this assay, from the lowest: compounds 2, 1 and 3 (each within the scatter of the next, the first and the last beyond it); then compound 4.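

In this assay, for the compounds shown here, the group on this amine nitrogen turns out to matter far more than the earlier compounds could show: pyridin-2-yl in place of 4-chloro-2-fluorophenyl gives a 130-fold higher number from compound 2 to compound 4 (2.10 log units; beyond the scatter), a large step where the only earlier one stayed within the scatter. Nothing available explains this step.

The whole aromatic ring changes at once, so the shares of the chlorine, the fluorine and the ring nitrogen remain unseparated. A plain phenyl or a 4-chlorophenyl on this nitrogen would help tell them apart.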